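From propylamino to piperidin-1-yl on a carbonyl carbon

The source may hold more compounds than are shown below. What is called first, only, known or untested is meant among the compounds shown, and "the series" means these compounds.

Compound 1 `CCCCCCc1cn(-c2ccc(O)c(C(=O)N3CCCCC3)c2)nn1`: > 20000 nM
Compound 2 `CCCNC(=O)c1ccc(-n2cc(-c3ccccc3)nn2)cc1O`: > 20000 nM
Compound 3 `CCCCCc1ccc(-c2cn(-c3ccc(C(=O)NCCC)c(O)c3)nn2)cc1`: > 20000 nM

All three compounds were tested in a functional assay on RAW264.7 cells (Mus musculus) for inhibition, read by Griess assay, with a stated time of 20 h; on this read-out higher numbers stand for weaker inhibition and lower numbers for stronger inhibition. Compound 3 gives > 20000 nM, which is a limit of the assay and not a number. It shares that position with the other two compounds: the limit of > 20000 nM in this assay, at which 3 of the 3 values shown sit.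

The next compound, compound 4 `CCCCCc1ccc(-c2cn(-c3ccc(C(=O)N4CCCCC4)c(O)c3)nn2)cc1`, carries one structural change, piperidin-1-yl in place of propylamino on a carbonyl carbon. Among the compounds with values here, the only measured single change is a step that the two limits leave unreadable from compound 2 to compound 3. It concerns a different place and offers no size to carry over. Compound 1 also carries the (piperidin-1-yl)carbonyl group. Compound 1 gives > 20000 nM, again a limit.

With no readable step to go on, no shift beyond the scatter and no direction is expected in this assay, and another limit is the likeliest report. The expected step is a number no higher from compound 3 to compound 4 (the limit leaves the size open). Compound 4 is estimated at 20000 nM, with an expected range of 8000 nM to 40000 nM.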

Compound 4, half-maximal inhibitory concentration: > 20000 nM
Compound 4: a limit, no number; the forecaster's own chance of this, stated with the estimate: 70%; the middle value lies on the limit itself.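

In this assay compound 4 gives > 20000 nM, which is a limit and not a number. Compound 3 also stands at a limit, and no step can be read between compound 3 and compound 4. The compounds shown leave open whether piperidin-1-yl in place of propylamino changes inhibition at all.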